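A few compounds are considered here, and "the series" means these few. Any claim that something is new, unique, unknown or untested is made for them only; others in the source may bear on it.

For the measured compounds named here, compound 1 `COc1ccc(CNC(=O)/C(C#N)=C/c2ccco2)cc1` is the only compound with a number in a functional assay on BE(2)-C cells (Homo sapiens) for inhibition, read by MTT assay, with a stated time of 72 h (a lower number here means a stronger inhibitor of growth, a higher number a weaker inhibitor of growth), where compound 1 gives 24000 nM. Compound 2 `COc1ccc(CNC(=O)/C(C#N)=C/c2ccc(-c3ccccc3)o2)cc1` reaches only a limit of the assay, > 100000 nM. Hence an at least 4.1-fold higher number from compound 1 to compound 2 (0.61 log units; beyond the scatter), a step that rests on (the limit of > 100000 nM in this assay, at which 1 of the 2 values shown sits). Compound 3 `COc1ccc(CNC(=O)/C(C#N)=C/c2cc(Br)co2)cc1` differs from compound 1 by bromo in place of hydrogen on an aromatic carbon, a smaller group than the phenyl of compound 2. Going by the values given here, only that one step bears on it, so a weakening smaller than that one, or none beyond the scatter, is expected, as a 1.3-fold higher number from compound 1 to compound 3 (0.10 log units; within the scatter). Compound 3 is therefore estimated at 30000 nM, within 10000 nM to 100000 nM.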

Compound 3, concentration for 50% growth inhibition: 36000 nM
The estimate for compound 3 lay 1.2-fold (0.08 log units) below the measured number; the measured number falls inside the stated range.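

Bromo in place of hydrogen gives a 1.5-fold higher number from compound 1 to compound 3 (0.18 log units; within the scatter) in this assay. This aromatic carbon, two ring bonds from the ring oxygen, therefore carries a bromo of 1 heavy atom with no change that can be told from the scatter. The earlier step to compound 2 had shown only a loss with phenyl, and its size remains open: the limit of > 100000 nM in this assay, at which 1 of the 3 values shown sits.

Going by these compounds, whether a methyl, an amine or a carboxylic acid at this carbon would also leave the number unchanged remains open. So does whether any group here would give a stronger inhibitor of growth than compound 1.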